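The compounds below may be only part of what the source reports. "The series", "measured", "known", "first", "only" and "open" are said of these compounds alone.

Measured compounds:
Compound 1, `O=C(O)CCc1cccc2c1B(O)OC2`: > 100000 nM
Compound 2, `CCNC(=O)CCc1cccc2c1B(O)OC2`: > 100000 nM

In a functional assay on HCT-116 cells (Homo sapiens) for antiproliferative activity, read by MTT assay, with a stated time of 72 h (on this read-out higher numbers stand for weaker inhibition and lower numbers for stronger inhibition), compound 1 gives only a limit, > 100000 nM. In this assay compound 2 likewise gives only a limit, > 100000 nM. Both values sit at the limit of > 100000 nM in this assay, at which 2 of the 2 values shown sit, so the step that the two limits leave unreadable from compound 1 to compound 2 cannot be read. Compound 3, `CC(C)(C)NC(=O)CCc1cccc2c1B(O)OC2`, is not yet measured; it differs from compound 2 by tert-butyl in place of ethyl on an amide-type nitrogen. Within the data shown here, the one measured step bears on it only in that neither of its ends reached a number. Nothing here points to stronger inhibition, so compound 3 is expected to give 150000 nM, within 50000 nM to 500000 nM. The expected step is a step that the limit leaves unreadable from compound 2 to compound 3, most likely again only a limit.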

Compound 3, half-maximal inhibitory concentration: > 100000 nM
Compound 3 ended at the assay's limit (the forecaster's own chance of this, stated with the estimate: 85%); the middle value does not contradict the limit.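

Among these compounds, no step among compound 1, compound 2 and compound 3 can be read, because all three give a limit rather than a number: the limit of > 100000 nM in this assay, at which 3 of the 3 values shown sit. The compounds shown leave open whether any change to the amide group would give a measurable value.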